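Swapping the benzyl aryl group: from difluoro to cyano

The source may report more compounds than this note shows. Statements on the series, on what has been measured and on what is new or still open speak of the compounds shown alone.

Measured compounds:
- compound 1, `CC(C)(N)C(=O)N[C@H](COCc1ccc(F)cc1F)c1nnnn1CCOC(=O)NCCCCO`: 0.42 nM
- compound 2, `CC(C)(N)C(=O)N[C@H](COCc1ccccc1Cl)c1nnnn1CCOC(=O)NCCCCO`: 0.45 nM
- compound 3, `CC(C)(N)C(=O)N[C@H](COCc1cccc(OC(F)(F)F)c1)c1nnnn1CCOC(=O)NCCCCO`: 3.1 nM

In a functional assay on cells for inhibition of growth hormone secretagogue receptor type 1 (Homo sapiens), read by FLIPR and calcium flux (a lower number here means that less compound is needed, a higher number that more compound is needed for the effect), compound 1 gives the lowest of the three numbers, though compound 2 sits within the scatter of it, so the two cannot be ordered; compound 3 lies further away, with a 7.4-fold higher number from compound 1 to compound 3 (0.87 log units; beyond the scatter).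

Compound 4, `CC(C)(N)C(=O)N[C@H](COCc1ccccc1C#N)c1nnnn1CCOC(=O)NCCCCO`, has not been measured. It differs from compound 1 in one place: 2-cyanophenyl in place of 2,4-difluorophenyl on a saturated chain carbon bound to an oxygen on a saturated carbon

Among the measured compounds shown here, two measured steps bear on this change, both exchanges of the same aryl group at the same place. The step of a 1.1-fold higher number from compound 1 to compound 2 (0.03 log units; within the scatter) shows that a single substituent at the 2-position of that phenyl ring leaves the number essentially unchanged. The step of a 6.9-fold higher number from compound 2 to compound 3 (0.84 log units; beyond the scatter), like a 7.4-fold higher number from compound 1 to compound 3 (0.87 log units; beyond the scatter), shows a modest loss when the substituent moves to the 3-position. The 2-cyanophenyl of compound 4 resembles the 2-chlorophenyl case more closely than the 3-substituted case, so in this assay the step is expected to be small, at most a slight rise, with a 1.7-fold higher number from compound 1 to compound 4 (0.22 log units; within the scatter) as the expected move.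

Compound 4 is therefore estimated at 0.7 nM in this assay, with a range from 0.25 nM to 2.5 nM.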

Compound 4, half-maximal effective concentration: 1.26 nM
Compound 4: middle estimate off by 1.8-fold (0.26 log units), on the low side; the range from low to high includes it.
By their numbers in this assay, from the lowest: compounds 1 and 2 (each within the scatter of the next); then compound 4; then compound 3.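

In this assay, the 2-cyanophenyl group shows that the aryl group at this place does not stay level merely by being swapped for another 2-substituted ring: cyano in place of chloro on the aromatic carbon gives a step beyond the scatter (a 2.8-fold higher number from compound 2 to compound 4 (0.45 log units; beyond the scatter)), and the exchange from 2,4-difluorophenyl does too (a 3.0-fold higher number from compound 1 to compound 4 (0.48 log units; beyond the scatter)). Compound 4 still lies clear of the 3-(trifluoromethoxy)phenyl case (a 2.5-fold lower number from compound 3 to compound 4 (0.39 log units; beyond the scatter)), so it takes an intermediate place among these aryl exchanges. Nothing available explains these steps.

The compounds shown leave open how an amine, a carboxylic acid or a methoxy group would read on this ring in place of the nitrile. They also leave open whether the step from chloro to cyano would hold with a longer chain on the shared core.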